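A few compounds are considered here, and "the series" means these few. Any claim that something is new, unique, unknown or untested is made for them only; others in the source may bear on it.

Of the compounds shown here, two built on one shared core have been measured in an assay on isolated protein (strain Charles River) for antagonist activity at histamine H2 receptor (Rattus norvegicus); on this read-out lower numbers stand for an effect already at smaller amounts and higher numbers for an effect only at larger amounts of compound. Compound 1 `Cc1ccc2ccc(=O)n(CCN(C)C)c2n1` gives 2.18 ug/mL. Compound 2 `CCc1ccc2ccc(=O)n(CCN(C)C)c2n1` gives 0.79 ug/mL, the lowest of the two numbers. The step of a 2.8-fold lower number from compound 1 to compound 2 (0.44 log units; beyond the scatter) arises from methyl in place of hydrogen on a saturated chain carbon bound to an aromatic carbon. Compound 3 `CC(C)c1ccc2ccc(=O)n(CCN(C)C)c2n1` carries that kind of change one bond further out: methyl in place of hydrogen on a saturated chain carbon bound to an aromatic carbon and a saturated chain carbon, so the ethyl side chain becomes isopropyl. Among the compounds with values here, the only measured step that bears on this is the one from compound 1 to compound 2, a modest lowering beyond the scatter, and a lowering in the same direction is expected again, although a second added methyl need not repeat the full gain of the first. For compound 3 the estimated step is a 1.6-fold lower number from compound 2 to compound 3 (0.20 log units; within the scatter). Compound 3 is therefore expected to give 0.5 ug/mL in this assay, with a range from 0.22 ug/mL to 1.2 ug/mL.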

Compound 3, half-maximal effective concentration: 0.6 ug/mL
Compound 3: the middle estimate sits 1.2-fold (0.08 log units) below what was measured; the measured number falls inside the stated range.
By their numbers in this assay, from the lowest: compounds 3 and 2 (each within the scatter of the next); then compound 1.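

In this assay the first added methyl gave a 2.8-fold lower number from compound 1 to compound 2 (0.44 log units; beyond the scatter) but the second, on the saturated chain carbon bound to an aromatic carbon and a saturated chain carbon, gives a 1.3-fold lower number from compound 2 to compound 3 (0.12 log units; within the scatter) and so leaves ethyl and isopropyl indistinguishable on this read-out. Measured against the methyl of compound 1, isopropyl gives a 3.6-fold lower number from compound 1 to compound 3 (0.56 log units; beyond the scatter) and thus keeps the difference first seen with ethyl, so branching at this carbon does not undo it. Nothing available explains these numbers.

As far as these compounds go, whether a tert-butyl group, with one more methyl on that same carbon, would move the number beyond the scatter remains open. So does whether a straight propyl chain or a cyclopropyl ring would match isopropyl on this read-out.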